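Dimethoxyphenyl for dichlorophenyl on a thiazolyl-ketone pyrimidinone

This account rests on a few compounds, and the source may have more. Where it says the series, first, only, none or still open, it means among the compounds named here.

Measured compounds:
Compound 1, `Cc1nc(-c2ccc(Cl)cc2)sc1C(=O)CSc1nc(-c2ccccc2)c(C#N)c(=O)[nH]1`, 83.1%
Compound 2, `Cc1nc(-c2ccc(Cl)cc2)sc1C(=O)CSc1nc(-c2ccc(Cl)c(Cl)c2)c(C#N)c(=O)[nH]1`, 97.1%
Compound 3, `Cc1nc(-c2ccccc2)sc1C(=O)CSc1nc(-c2ccc(Cl)c(Cl)c2)c(C#N)c(=O)[nH]1`, 92.5%

Of the compounds shown here, three sharing one core have been tested in a functional assay on U-87MG ATCC cells for antiproliferative activity against U-87 MG (Homo sapiens), read by MTT assay, with a stated time of 48 h, tested at 10 uM; on this read-out higher numbers stand for a weaker effect at the one concentration tested and lower numbers for a stronger effect. Compound 2 gives the highest number of the three; compound 3 lies closest to it, a number 4.6 percentage points lower from compound 2 to compound 3 (within the scatter), while compound 1 is furthest away, a number 14 percentage points higher from compound 1 to compound 2 (beyond the scatter).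

Compound 4, `COc1ccc(-c2nc(SCC(=O)c3sc(-c4ccc(Cl)cc4)nc3C)[nH]c(=O)c2C#N)cc1OC`, has not yet been measured. It differs from compound 2 in one place: 3,4-dimethoxyphenyl in place of 3,4-dichlorophenyl on an aromatic carbon. Among the measured compounds shown here, only one measured step touches this aromatic carbon, the replacement that carries compound 1 to compound 2, and it moved the read-out by a modest amount beyond the scatter. For the measured compounds named here, no measured pair exchanges a dichlorophenyl for a dimethoxyphenyl, so the direction of the change cannot be read from the data. Given that compound 2 already sits near the top of the scale, compound 4 is expected to show a number 7.1 percentage points lower from compound 2 to compound 4 (within the scatter), in this assay giving an estimated 90%, with a range from 72% to 100%.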

Compound 4, a percentage reported as activity, at one concentration (the size of the read-out at that concentration, not a potency): 83.3%
Beside the measured number, compound 4's estimate is 6.7 percentage points above it; low and high end bracket the measured number.
By their numbers in this assay, from the lowest: compounds 1, 4, 3 and 2 (each within the scatter of the next, the first and the last beyond it).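

At this aromatic carbon, 3,4-dimethoxyphenyl in place of 3,4-dichlorophenyl gives, in this assay, a number 13.8 percentage points lower from compound 2 to compound 4 (beyond the scatter), so two groups that each carry two substituents on the same ring positions do not read alike here. Set against the plain phenyl, the 3,4-dimethoxyphenyl group gives a number 0.2 percentage points higher from compound 1 to compound 4 (within the scatter), which leaves 3,4-dichlorophenyl as the one group of these three at this carbon that stands apart, with the weaker effect at the single concentration tested. Nothing available here accounts for this difference between the groups.

From the compounds shown here alone, whether the same exchange reads alike on the core of compound 3 stays open. Also open, going by these compounds, is how an amine, a carboxylic acid or a longer alkoxy chain would read at this aromatic carbon.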